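The compounds below may be only part of what the source reports. "The series", "measured", "known", "first", "only" and "open" are said of these compounds alone.

In a functional assay on L1210 cells (Mus musculus) for cytotoxicity (on this read-out higher numbers stand for weaker inhibition and lower numbers for stronger inhibition), compound 1 (`CN1CCc2cccc(c2)Oc2ccc(cc2)CCC1=O`) reaches only a limit and not a number, > 100 ug/mL. Compound 2 (`O=C1CCc2ccc(cc2)Oc2cccc(c2)CCN1`) also gives only a limit, > 100 ug/mL. Within the data shown here, the one measured step is a step that the two limits leave unreadable from compound 1 to compound 2, so it offers no size to carry forward, and it concerns the ring nitrogen rather than an aromatic carbon. Compound 3 (`COc1ccc2cc1Oc1ccc(cc1)CCC(=O)N(C)CC2`) differs from compound 1 by methoxy in place of hydrogen on an aromatic carbon, which is methoxy in place of hydrogen on an aromatic carbon. Among the measured compounds shown here, with no measured step bearing on this change, no clear shift in either direction is expected. The expected step is a number no higher from compound 1 to compound 3 (the limit leaves the size open). Compound 3 is estimated at 100 ug/mL, with an expected range from 40 ug/mL to 200 ug/mL.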

Compound 3, half-maximal inhibitory concentration: > 100 ug/mL
Compound 3: no number, only a limit; the forecaster's own chance of this, stated with the estimate: 70%; the middle value lies on the limit itself.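

No step can be read from compound 1 to compound 3, because both compounds give only a limit and not a number: the limit of > 100 ug/mL in this assay, at which 3 of the 3 values shown sit.

On these data alone, whether methoxy in place of hydrogen changes the inhibition of compound 1 at all remains open.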